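Imidazolylmethyl in Place of the Ester Chain on Nitrogen

The compounds below may be only part of what the source reports. "The series", "measured", "known", "first", "only" and "open" are said of these compounds alone.

This account concerns three measured compounds sharing one core and a fourth that awaits measurement. Compound 1 `CCOC(=O)CN(c1ccccc1)[C@H]1c2cc(C#N)ccc2OC(C)(C)[C@@H]1O` carries an (ethoxycarbonyl)methyl group on the nitrogen on an aromatic ring. In a functional assay (aorta) with Rattus norvegicus as the target (a lower number here means a stronger inhibitor, a higher number a weaker inhibitor), compound 1 gives > 30000 nM, which is a limit of the assay rather than a number. Compound 2 `CC1(C)Oc2ccc(C#N)cc2[C@H](Nc2ccccc2)[C@H]1O` has hydrogen in that place, and in this assay compound 2 gives 1200 nM. Compound 3 `CC1(C)Oc2ccc(C#N)cc2[C@H](N(Cc2ncco2)c2ccccc2)[C@H]1O` carries an (1,3-oxazol-2-yl)methyl group there; in this assay compound 3 gives > 30000 nM, again a limit of the assay.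

The step from compound 1 to compound 2 was an at least 25-fold lower number from compound 1 to compound 2 (1.39 log units; beyond the scatter), and the step from compound 2 to compound 3 was an at least 25-fold higher number from compound 2 to compound 3 (1.39 log units; beyond the scatter). Between compound 1 and compound 3 the step is a step that the two limits leave unreadable from compound 1 to compound 3, since both sit at the limit (the limit of > 30000 nM in this assay, at which 2 of the 3 values shown sit).

Compound 4 `CC1(C)Oc2ccc(C#N)cc2[C@H](N(Cc2ncc[nH]2)c2ccccc2)[C@H]1O` differs from compound 1 as follows: 1H-imidazol-2-yl in place of ethoxycarbonyl on a saturated chain carbon bound to a nitrogen on an aromatic ring. Both substituted nitrogens measured so far sit at the limit, so the same is expected for compound 4, with the step from compound 1 to compound 4 estimated as a step that the limit leaves unreadable from compound 1 to compound 4. Compound 4 is therefore expected to give about 40000 nM in this assay, within 8000 nM to 200000 nM, most likely reported only as a limit.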

Compound 4, half-maximal inhibitory concentration: > 30000 nM
Compound 4 gave a limit, no number; the forecaster's own chance of this, stated with the estimate: 80%; the middle value is on the limit's open side.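

In this assay compound 4 gives > 30000 nM, which is a limit of the assay and not a number. Against the hydrogen of compound 2 the change is an at least 25-fold higher number from compound 2 to compound 4 (1.39 log units; beyond the scatter), so (1H-imidazol-2-yl)methyl, the first group shown on this nitrogen with a hydrogen-bond donor, joins (ethoxycarbonyl)methyl and (1,3-oxazol-2-yl)methyl, and among the four compounds only the one with hydrogen on this nitrogen gives a number rather than a limit. The steps from compound 4 to compound 1 and to compound 3 cannot be read, and the three substituted compounds cannot be placed in any order, because all of them stop at the same limit: the limit of > 30000 nM in this assay, at which 3 of the 4 values shown sit.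

The compounds shown leave open whether any group on this nitrogen other than hydrogen can give a readable value, for instance a plain methyl or ethyl group, or an aminoethyl chain. They also leave open whether the imidazole ring would read differently on a longer chain, as in 2-(1H-imidazol-2-yl)ethyl, or with a methyl group on its ring nitrogen.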